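Biaryl Replaces Nitrile on a Piperidine Sulfonamide

A few compounds are considered here, and "the series" means these few. Any claim that something is new, unique, unknown or untested is made for them only; others in the source may bear on it.

Compound 1 `CC1CCN(C2CCN(S(=O)(=O)c3ccc(C(C)(C)C)cc3)CC2)CC1`: in an ADME assay on HCT-116 cells (Homo sapiens) for cytotoxicity, read by CellTiter-Glo, with a stated time of 72 h (on this read-out lower numbers stand for stronger inhibition and higher numbers for weaker inhibition), compound 1 gives > 5000 nM, a limit of the assay.
Compound 2 `CCc1ccc(S(=O)(=O)N2CCC(N3CCC(C)CC3)CC2)cc1`: in this assay compound 2 gives > 5000 nM, also a limit.
Compound 3 `CC1CCN(C2CCN(S(=O)(=O)c3ccc(C#N)cc3)CC2)CC1`: in this assay compound 3 gives > 5000 nM, again a limit.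

Compound 3 thus stands only at a limit, with no number of its own, and the other two values shown are limits as well, which is seen in the limit of > 5000 nM in this assay, at which 3 of the 3 values shown sit. The steps a step that the two limits leave unreadable from compound 1 to compound 3 and a step that the two limits leave unreadable from compound 2 to compound 3, both changing the same aromatic carbon, cannot be read either. Compound 4 `CC1CCN(C2CCN(S(=O)(=O)c3ccc(-c4ccc(Cl)cc4)cc3)CC2)CC1` differs from compound 3 by 4-chlorophenyl in place of cyano on an aromatic carbon. Among the compounds with values here, no measured step bears on this change, so no size or direction beyond the scatter can be drawn from the data. The step that the limit leaves unreadable from compound 3 to compound 4 is therefore only an estimate resting on the shared limit. Compound 4 is expected to give about 8000 nM, within a range from 2000 nM to 30000 nM.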

Compound 4, half-maximal inhibitory concentration: > 5000 nM
Compound 4: no number, only a limit; the forecaster's own chance of this, stated with the estimate: 60%; the middle value lies beyond the limit too.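

Compound 4 also gives only a limit, so the steps to it from compound 1, compound 2 and compound 3 cannot be read: the limit of > 5000 nM in this assay, at which 4 of the 4 values shown sit.

The compounds shown leave open whether tert-butyl, ethyl, cyano and 4-chlorophenyl differ at all in this assay.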